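This account rests on a few compounds, and the source may have more. Where it says the series, first, only, none or still open, it means among the compounds named here.

- Compound 1 `CCCOc1c(OC)cc2oc(-c3ccccc3)cc(=O)c2c1O` in a functional assay on KB 3-1 cells (Homo sapiens) for inhibition, with a stated time of 72 h (on this read-out higher numbers stand for weaker inhibition and lower numbers for stronger inhibition), gives > 100000 nM, a limit and not a number.
- Compound 2 `CCOc1cc2oc(-c3ccccc3)cc(=O)c2c(O)c1OCC` in this assay gives > 100000 nM, also a limit and not a number.

Compound 2 therefore has no exact position on this scale. It stands with compound 1 at the one place the data show: the limit of > 100000 nM in this assay, at which 2 of the 2 values shown sit. Compound 3 `CCOc1c(OC)cc2oc(-c3ccccc3)cc(=O)c2c1O` departs from compound 2 by a single small change, (hydrogen in place of methyl on a saturated chain carbon bound to an oxygen on an aromatic ring), which is hydrogen in place of methyl on a saturated chain carbon bound to an oxygen on an aromatic ring, or ethoxy to methoxy. Among the compounds with values here, no measured step shows what such a change does in this assay. With so small a change, no gain in inhibition is expected. The expected a number no higher from compound 2 to compound 3 (the limit leaves the size open) is none beyond the scatter. Compound 3 is expected at 100000 nM, with an estimated range of 40000 nM to 200000 nM, and most likely only as a limit.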

Compound 3, half-maximal inhibitory concentration: > 100000 nM
Compound 3 was reported as a limit (the forecaster's own chance of this, stated with the estimate: 85%); the middle value lies on the limit itself.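

Compound 1, compound 2 and compound 3 all give a limit and not a number, so neither the step from compound 2 to compound 3 nor that from compound 1 to compound 3 can be read: the limit of > 100000 nM in this assay, at which 3 of the 3 values shown sit.

The compounds shown leave open whether ethoxy to methoxy changes inhibition at all in this assay.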